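Swapping the ring-bound heteroatom on a stable exocyclic scaffold

This account rests on a few compounds, and the source may have more. Where it says the series, first, only, none or still open, it means among the compounds named here.

Compound 1 `CC(C)[C@@H](C[C@H]1SC(=O)NC1=O)c1ccc(-c2ccc3cccc(F)c3c2)[nH]c1=O` and compound 3 `CC(C)[C@@H](c1ccc(-c2ccc3cccc(F)c3c2)[nH]c1=O)[C@@H]1OC(=O)NC1=O` share a core with compound 2 `C/C(=C1/OC(=O)NC1=O)C(c1ccc(-c2ccc3cccc(F)c3c2)[nH]c1=O)C(C)C`. In an ADME assay on microsomes from liver (Rattus norvegicus) for metabolic stability (a higher number here means that the compound lasts longer, a lower number that the compound disappears faster), compound 1 gives 0.77 h, while compound 3 gives 1.27 h. Compound 2 reaches only a limit of this assay, > 3 h, and that limit is where it stands among the three measured values, as noted in the limit of > 3 h in this assay, at which 1 of the 3 values shown sits. Compound 4 `CC(C)C(/C=C1\NC(=O)NC1=O)c1ccc(-c2ccc3cccc(F)c3c2)[nH]c1=O` differs from compound 2 by a group of 8 heavy atoms (4 carbon, 2 nitrogen, 2 oxygen; one five-membered non-aromatic ring with 2 hetero atoms) in place of a group of 9 heavy atoms (5 carbon, 1 nitrogen, 3 oxygen; one five-membered non-aromatic ring with 2 hetero atoms), on a saturated chain carbon bound to an aromatic carbon and a saturated chain carbon. Going by the values given here, with no measured step of this kind to lean on, a shift from compound 2 to compound 4 of an at least 1.2-fold lower number from compound 2 to compound 4 (0.07 log units; that floor lies within the scatter) is expected, which is within the usual scatter. Compound 4 is therefore estimated at 2.5 h, with a range of 1 h to 4 h.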

Compound 4, half-life: 1.46 h
Compound 4: the middle estimate sits 1.7-fold (0.23 log units) above what was measured; the range from low to high includes it.
By their numbers in this assay, from the lowest: compounds 1, 3 and 4 (each within the scatter of the next). At a limit, above all of these: compound 2.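

Going by these compounds alone, this is the first readable step at the saturated chain carbon bound to an aromatic carbon and a saturated chain carbon: placing the group with 2 nitrogen and 2 oxygen where the group with 1 nitrogen and 3 oxygen stood gives an at least 2.0-fold lower number from compound 2 to compound 4 (0.31 log units; beyond the scatter) in this assay. So the makeup of this ring group matters to the half-life. That size is only a floor, since compound 2 stands at a limit of the assay: the limit of > 3 h in this assay, at which 1 of the 4 values shown sits.

One step cannot separate the two groups' differences in atoms and hydrogen-bond donors. From the compounds shown here alone, how a carboxylic acid at this place would fare also remains open.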